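Series notes: aryl ether amines, cyclopropyl for methyl

The compounds below may be only part of what the source reports. "The series", "measured", "known", "first", "only" and "open" are said of these compounds alone.

Measured so far in an assay on brain (strain C57BL6) for displacement of a labelled ligand from AP2-associated protein kinase 1 (Mus musculus), read by scintillation counting, with a stated time of 1 h; on this read-out higher numbers stand for weaker inhibition and lower numbers for stronger inhibition:
- compound 2 `COC(=O)Nc1cc(-c2ccc(OC[C@@](C)(N)CC(C)C)c(C)c2)ccn1` gives 0.08 nM
- compound 3 `COC(=O)Nc1cc(-c2ccc(OC[C@@](C)(N)CC(C)C)c(C)c2C)ccn1` gives 0.26 nM
- compound 1 `CC(=O)Nc1cc(-c2ccc(OC[C@@H](N)CC(C)C)c(F)c2)ccn1` gives 0.52 nM

Compound 2 holds the lowest number of the three in this assay; compound 3 lies nearest, compound 1 furthest, and both gaps lie beyond the usual scatter.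

The next compound, compound 4 `COC(=O)Nc1cc(-c2ccc(OC[C@@](C)(N)CC(C)C)c(C3CC3)c2)ccn1`, differs from compound 2 in one place: cyclopropyl in place of methyl on an aromatic carbon. The methyl that sits on an aromatic carbon, ortho to the (2-amino-2,4-dimethylpentyl)oxy group and meta to a large group, is replaced by cyclopropyl.

Going by the values given here, only one measured step touches the same aromatic ring: a 3.3-fold higher number from compound 2 to compound 3 (0.51 log units; beyond the scatter), where an additional methyl enters on an aromatic carbon. That change enlarged the substitution on the ring and gave a modest rise in the number. The change to compound 4 also enlarges what sits on that ring, though at the position already carrying methyl, so a step of similar or smaller size toward a higher number is expected in this assay, with a result within the scatter of compound 2 also possible.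

For compound 4 the estimate in this assay is 0.15 nM, with a range from 0.05 nM to 0.5 nM. This estimate for compound 4 means an expected step of a 1.9-fold higher number from compound 2 to compound 4 (0.27 log units; within the scatter).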

Compound 4, inhibition constant: 0.05 nM
Beside the measured number, compound 4's estimate is 3.0-fold (0.48 log units) above it; measured number inside the range.
By their numbers in this assay, from the lowest: compounds 4 and 2 (each within the scatter of the next); then compounds 3 and 1 (each within the scatter of the next).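

In this assay the aromatic carbon ortho to a (2-amino-2,4-dimethylpentyl)oxy group accepts cyclopropyl in place of methyl, with a 1.6-fold lower number from compound 2 to compound 4 (0.20 log units; within the scatter) as the step, so compound 2 and compound 4 stand level here although the entering group has 3 heavy atoms against 1 and brings a three-membered ring. The other step on this aromatic ring, a 3.3-fold higher number from compound 2 to compound 3 (0.51 log units; beyond the scatter) as an added methyl, lies beyond the scatter, so more carbon on the ring does not by itself go with a higher number in the compounds shown. Nothing available bears on why the number holds at this position with the larger group.

As far as these compounds go, it remains open whether the number also holds with larger or different groups at this place, such as isopropyl, cyclobutyl, tert-butyl, methoxy or chlorine, and so where the limit of this position lies. From the compounds shown here alone, it is also open whether cyclopropyl would give the same picture on the core of compound 1, which carries fluorine at this place and an acetamide in place of the methyl carbamate.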